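The compounds below may be only part of what the source reports. "The series", "measured", "known", "first", "only" and "open" are said of these compounds alone.

Measured compounds:
Compound 1, `COc1ccc(NC(=O)C(=O)c2cc(C(C)C)n3ccccc23)cn1`: < 0.0834 h
Compound 2, `COCCn1cc(C(=O)C(=O)Nc2ccc(OC(C)C)nc2)c2ccccc21`: 1.65 h

In an ADME assay on liver (Mus musculus, strain CD-1) for metabolic stability, read by LC-MS, using microsomes and NADPH, with a stated time of 5 min, tested at 1 uM (a higher number here means that the compound lasts longer, a lower number that the compound disappears faster), compound 1 gives < 0.0834 h, which is a limit of the assay and not a number. Compound 2 gives 1.65 h in this assay. So compound 1 stands at the limit of < 0.0834 h in this assay, at which 1 of the 2 values shown sits. Compound 3, `COCCc1cc(C(=O)C(=O)Nc2ccc(OC)nc2)c2ccccn12`, differs from compound 1 by 2-methoxyethyl in place of isopropyl on an aromatic carbon. Among the compounds with values here, no measured step links these two compounds, so a step beyond the scatter in this assay is not assured in either direction; a modest rise is expected, as described by an at least 1.4-fold higher number from compound 1 to compound 3 (0.15 log units; that floor lies within the scatter). For compound 3 the expected half-life in this assay is 0.12 h, with a range from 0.04 h to 0.4 h.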

Compound 3, half-life: 0.1 h
Beside the measured number, compound 3's estimate is 1.2-fold (0.08 log units) above it; the range from low to high includes it.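

At this position, on an aromatic carbon next to the ring nitrogen, 2-methoxyethyl in place of isopropyl yields a measured number in this assay, with compound 3 at 0.1 h. The change reads as an at least 1.1-fold higher number from compound 1 to compound 3 (0.07 log units; that floor lies within the scatter), which gives only a floor for the step and not its full size. Compound 1 stands at a limit of the assay and not a number: the limit of < 0.0834 h in this assay, at which 1 of the 3 values shown sits.

From the compounds shown here alone, the true size of the step remains open. So does how an amine, a carboxylic acid or a longer ether chain at this place would read in this assay.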